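A few compounds are considered here, and "the series" means these few. Any claim that something is new, unique, unknown or untested is made for them only; others in the source may bear on it.

Working notes on the series. Three compounds carry a number in an assay on HEK293 cells for agonist activity at transient receptor potential cation channel subfamily M member 8 (Homo sapiens), read by fluorescence and calcium flux, with a stated time of 15 min; a lower number here means that less compound is needed, a higher number that more compound is needed for the effect. Compound 1 `CCN(Cc1cccs1)C(=O)COc1ccc(OC)cc1` gives 120 nM in this assay. Compound 2 `Cc1ccc(OCC(=O)N(Cc2cccs2)C2CC2)cc1` gives 8 nM in this assay, and compound 3 `CCN(Cc1cc[nH]c1)C(=O)COc1ccc(C)cc1` gives 21800 nM. Compound 2 holds the lowest number of the three; compound 1 is the nearest and compound 3 the furthest, and both gaps lie beyond the scatter. Among the compounds with values here, no pair of measured compounds differs in only one place, so no single step between them can be quoted; the three differ from one another in several places at once.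

The next compound, compound 4 `Cc1ccc(OCC(=O)N(Cc2cccs2)c2nccn2C)cc1`, differs from compound 2 in one place: 1-methyl-1H-imidazol-2-yl in place of cyclopropyl on an amide-type nitrogen. Within the data shown here, nothing measured so far shows what a ring of this kind on the amide nitrogen does; compound 2 is the only compound with cyclopropyl at that nitrogen, and it sits at 8 nM, well apart from the rest. Among the measured compounds shown here, with no measured precedent for the change, an upward step is expected for compound 4, likely beyond the scatter, though its size is uncertain. The estimate for compound 4 in this assay is 150 nM, with a range from 30 nM to 1500 nM. The step this estimate means is expected to be a 19-fold higher number from compound 2 to compound 4 (1.27 log units; beyond the scatter).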

Compound 4, half-maximal effective concentration: 1790 nM
Beside the measured number, compound 4's estimate is 12-fold (1.08 log units) below it; measured number outside the range, above it.
By their numbers in this assay, from the lowest: compound 2; then compound 1; then compound 4; then compound 3.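

In this assay, within the data shown here, the amide nitrogen proves to be a sensitive position: 1-methyl-1H-imidazol-2-yl in place of cyclopropyl gives a 220-fold higher number from compound 2 to compound 4 (2.35 log units; beyond the scatter), the only step so far that isolates a change at one place. The step exchanges a three-membered non-aromatic ring of carbon only, with 3 heavy atoms and 0 hydrogen-bond acceptors, for a five-membered aromatic ring with 2 hetero atoms, 6 heavy atoms and 2 hydrogen-bond acceptors; these differences arrive together, and a single step cannot separate them. Nothing available bears on why the number rises with this change.

From the compounds shown here alone, it remains open whether a carbocyclic group such as cyclobutyl or phenyl on the amide nitrogen would stay close to compound 2 or move towards compound 4, which would help show whether the hetero atoms of the imidazole matter or the ring alone does. Going by these compounds, it is also open whether a step of this size would recur with a group other than the 4-methylphenoxy part shared by compound 2 and compound 4, such as a chloro group in place of that methyl.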